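This account rests on a few compounds, and the source may have more. Where it says the series, first, only, none or still open, it means among the compounds named here.

Compound 1 `CNC(=O)c1ccccc1Oc1nc(Nc2ccc(Br)cc2)ncc1Br` and compound 2 `CNC(=O)c1ccccc1Oc1nc(Nc2cccc(C(F)(F)F)c2)ncc1Br` share one core and differ in the aryl group on the amino nitrogen. In a functional assay on U-937 cells (Homo sapiens) for antiproliferative activity, read by MTT assay, with a stated time of 24 h (a lower number here means a stronger inhibitor, a higher number a weaker inhibitor), compound 1 gives only a limit, > 50000 nM, so its true value is not known. Compound 2 in this assay gives 45500 nM, a weak result that sits close to the limit of > 50000 nM in this assay, at which 1 of the 2 values shown sits. Compound 3 `CNC(=O)c1ccccc1Oc1nc(Nc2cccc(OC)c2)ncc1Br` has not been measured in this assay. It differs from compound 1 by 3-methoxyphenyl in place of 4-bromophenyl on a nitrogen on an aromatic ring, that is, (4-bromophenyl)amino to (3-methoxyphenyl)amino. Among the measured compounds shown here, no measured pair shows the effect of this change, and compound 2 shows that another aryl group in the same place leaves potency weak. The step from compound 1 to compound 3 is therefore expected to be small or absent beyond the scatter, an at least 1.2-fold lower number from compound 1 to compound 3 (0.09 log units; that floor lies within the scatter). Compound 3 is estimated to give 40000 nM in this assay, within a range from 12000 nM to 50000 nM.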

Compound 3, half-maximal inhibitory concentration: 24300 nM
Compound 3: middle estimate off by 1.6-fold (0.22 log units), on the high side; the measured number falls inside the stated range.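

In this assay, among the compounds shown here, 3-methoxyphenyl in place of 4-bromophenyl on the nitrogen gives an at least 2.0-fold lower number from compound 1 to compound 3 (0.31 log units; beyond the scatter), the first step at this position that can be read as lying beyond the scatter, and it shows that the number responds to the aryl group there. Methoxy in place of trifluoromethyl on the aromatic carbon gives a 1.9-fold lower number from compound 2 to compound 3 (0.27 log units; within the scatter), so the data do not separate these two groups. Compound 1 remains the only one of the three held at a limit, so the true size of its step stays unknown: the limit of > 50000 nM in this assay, at which 1 of the 3 values shown sits.

From the compounds shown here alone, the step from compound 1 changes both the group and its place on the aryl ring at once, so the share of each stays open. Also open, going by these compounds, is whether an amine or a carboxylic acid on that ring would carry the number further.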